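Half-life notes on a three-compound series

The source may report more compounds than this note shows. Statements on the series, on what has been measured and on what is new or still open speak of the compounds shown alone.

Measured so far:
compound 1 `CCCCN(c1nc2c(NC(C)=O)cccc2o1)[C@H](C)c1ccc(-c2ccccc2-c2nnn[nH]2)cc1` — 2.2 h
compound 2 `CCCCN(c1nc2c(C(=O)NC)cccc2o1)[C@H](C)c1ccc(-c2ccccc2-c2nnn[nH]2)cc1` — 1.3 h
compound 3 `CCCCN(c1nc2c(NS(C)(=O)=O)cccc2o1)[C@H](C)c1ccc(-c2ccccc2-c2nnn[nH]2)cc1` — 4.7 h

In an ADME assay on the whole organism (Macaca fascicularis) for metabolic stability, read by LC-MS, using cassette dosing, at a dose of 1 mg/kg by the oral route (a lower number here means that the compound disappears faster, a higher number that the compound lasts longer), compound 3 stands highest of the three: nearest is compound 1, a 2.1-fold higher number from compound 1 to compound 3 (0.33 log units; beyond the scatter); furthest is compound 2, a 3.6-fold higher number from compound 2 to compound 3 (0.56 log units; beyond the scatter). The step between compounds 1 and 2 is a 1.7-fold lower number from compound 1 to compound 2 (0.23 log units; within the scatter).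

Compound 4 `CCCCN(c1nc2c(-c3nccn3C)cccc2o1)[C@H](C)c1ccc(-c2ccccc2-c2nnn[nH]2)cc1` differs from compound 3 in one place: 1-methyl-1H-imidazol-2-yl in place of methanesulfonamido on an aromatic carbon. The measured steps all exchange groups at this same aromatic carbon, but none of them brings in an aromatic ring, so they bear on the change only loosely. They show that the three substituents span a modest range, with compound 3 at the top. The expected outcome is a modest fall back toward the values of compounds 1 and 2. For compound 4 the expected step is a 2.4-fold lower number from compound 3 to compound 4 (0.37 log units; beyond the scatter). Compound 4 is estimated at 2 h, with a range of 0.9 h to 4.5 h.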

Compound 4, half-life: 3.9 h
For compound 4 the middle estimate is 2.0-fold (0.29 log units) below the measured one; the range from low to high includes it.
By their numbers in this assay, from the lowest: compounds 2, 1, 4 and 3 (each within the scatter of the next, the first and the last beyond it).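

In this assay, 1-methyl-1H-imidazol-2-yl brings an aromatic ring onto this aromatic carbon and stays within the scatter of methanesulfonamido (a 1.2-fold lower number from compound 3 to compound 4 (0.08 log units; within the scatter)) and of acetamido (a 1.8-fold higher number from compound 1 to compound 4 (0.25 log units; within the scatter)). Only against methylcarbamoyl does the step go beyond the scatter (a 3.0-fold higher number from compound 2 to compound 4 (0.48 log units; beyond the scatter)), so a group with 0 hydrogen-bond donors can sit here without a step beyond the scatter from methanesulfonamido. No measurement at hand explains these steps. Open, as far as these compounds go, is whether an imidazol-2-yl without the methyl, or a pyridyl, would stay in this range. A carboxylic acid or an amine on this carbon also remains untested among the compounds shown.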